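This account rests on a few compounds, and the source may have more. Where it says the series, first, only, none or still open, it means among the compounds named here.

Measured compounds in a functional assay on the whole organism (stomach) for inhibition, with Rattus norvegicus as the target, at a dose of 100 mg/kg by the intraduodenal route; a higher number here means more inhibition at the dose given (going by the name of the read-out), a lower number less inhibition:
compound 1, `CC/N=C(\S)CCn1nc(-c2ccccc2)ccc1=O`: 50.3%
compound 2, `Cc1cc(=O)n(CCC(=N)S)nc1-c1ccccc1`: 32%
compound 3, `CC(CC(=N)S)n1nc(-c2ccccc2)ccc1=O`: 15.5%

Compound 3 stands lowest of the three numbers. Its nearest neighbour is compound 2, whose value lies higher by a gap beyond the scatter, and the furthest is compound 1, whose value lies higher by a gap also beyond the scatter. Compound 4, `N=C(S)CCn1nc(-c2ccccc2)ccc1=O`, has not yet been measured in this assay. It differs from compound 3 in one place: hydrogen in place of methyl on a saturated chain carbon bound to an aromatic nitrogen and a saturated chain carbon. For the measured compounds named here, no step between two measured compounds of this set differs in a single place, so the size of this change cannot be read off a measured pair. The two measured compounds with an unbranched chain, compound 1 and compound 2, both give higher numbers than compound 3, so an upward step is expected, of a moderate size that may reach beyond the scatter. The step from compound 3 to compound 4 is estimated at a number 14.5 percentage points higher from compound 3 to compound 4 (beyond the scatter). Compound 4 is accordingly expected to give about 30%, within a range from 10% to 55%.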

Compound 4, a percentage reported as inhibition, in the whole organism at one dose (the size of the read-out at that dose, not a potency): 53.7%
Compound 4: middle estimate off by 23.7 percentage points, on the low side; measured number inside the range.
By their numbers in this assay, from the lowest: compound 3; then compound 2; then compounds 1 and 4 (each within the scatter of the next).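

In this assay, hydrogen in place of methyl on a saturated chain carbon bound to an aromatic nitrogen and a saturated chain carbon gives a large step (a number 38.2 percentage points higher from compound 3 to compound 4 (beyond the scatter)), the first measured size for this change at this place. Hydrogen in place of methyl on an aromatic carbon gives a modest step (a number 21.7 percentage points higher from compound 2 to compound 4 (beyond the scatter)), so methyl at either place goes with less inhibition in these pairs, whereas a group of 3 heavy atoms in place of a group of 5 heavy atoms on a saturated chain carbon, two bonds along the chain from an aromatic nitrogen, leaves the numbers level (a number 3.4 percentage points higher from compound 1 to compound 4 (within the scatter)). No measurement offered here accounts for these steps.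

The compounds shown leave open how ethyl would behave on either carbon that carries methyl. They also leave open whether a carboxylic acid or an amine could take the place of the group of 3 heavy atoms.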